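A few compounds are considered here, and "the series" means these few. Any claim that something is new, unique, unknown or untested is made for them only; others in the source may bear on it.

Compound 1 `CCCCC[Se]c1nc(NCc2ccc(SC)cc2)c2ccccc2n1` stands as the only numbered result here: in a functional assay on CCRF-CEM cells (Homo sapiens) for cytotoxicity, read by MTT assay, with a stated time of 72 h (a lower number here means a stronger inhibitor of growth, a higher number a weaker inhibitor of growth), compound 1 gives 83900 nM. Compound 2 `CSc1ccc(CNc2nc([SeH])nc3ccccc23)cc1` gives > 100000 nM in this assay, a limit rather than a number, namely (the limit of > 100000 nM in this assay, at which 1 of the 2 values shown sits). Among the compounds with values here, the one measured step, an at least 1.1-fold higher number from compound 1 to compound 2 (0.07 log units; that floor lies within the scatter), is a hydrogen in place of pentyl on a selenium. Within the data shown here, compound 3 `CCCCC[Se]c1nc(NCc2ccccc2)c2ccccc2n1` differs from compound 1 by hydrogen in place of methylsulfanyl on an aromatic carbon, a change at a place no measured step touches, so the measured step bears only loosely on it. Compound 3 is therefore expected to sit near compound 1, estimated at 90000 nM with a range of 40000 nM to 200000 nM, a step of a 1.1-fold higher number from compound 1 to compound 3 (0.03 log units; within the scatter) within the scatter.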

Compound 3, concentration for total growth inhibition: 72500 nM
The estimate for compound 3 lay 1.2-fold (0.09 log units) above the measured number; the range from low to high includes it.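

Unlike the earlier step, which touched the selenium, this one tests the six-membered aromatic ring: in this assay the change from 4-(methylsulfanyl)phenyl to phenyl gives a 1.2-fold lower number from compound 1 to compound 3 (0.06 log units; within the scatter) and so no difference beyond the scatter. Compound 1's level of growth inhibition therefore does not depend on the methylsulfanyl group at this position. Nothing shown gives a reason for this result. From the compounds shown here alone, whether methoxy, chlorine or an amine at this position would shift the number remains open. So does the effect of a chain longer than pentyl on the selenium.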